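Adding a Methoxy Group to a Sulfonamide Series

A few compounds are considered here, and "the series" means these few. Any claim that something is new, unique, unknown or untested is made for them only; others in the source may bear on it.

Three compounds sharing one core were tested in an ADME assay on Li23 cells (Homo sapiens) for cytotoxicity, read by WST assay; on this read-out higher numbers stand for lower toxicity in this test and lower numbers for higher toxicity in this test. Compound 1 `Cc1ccccc1C(=O)N(C)c1ccc(C(O)(C(F)(F)F)C(F)(F)F)cc1` gives 38000 nM. Compound 2 `CN(C(=O)C1CCCCC1)c1ccc(C(O)(C(F)(F)F)C(F)(F)F)cc1` gives 20000 nM, and compound 3 `CN(c1ccc(C(O)(C(F)(F)F)C(F)(F)F)cc1)S(=O)(=O)c1ccccc1` gives 16000 nM. The step of a 1.9-fold lower number from compound 1 to compound 2 (0.28 log units; within the scatter) is small, the step of a 2.4-fold lower number from compound 1 to compound 3 (0.38 log units; beyond the scatter) is modest but beyond the scatter, and the step of a 1.3-fold lower number from compound 2 to compound 3 (0.10 log units; within the scatter) is within it. Compound 3 therefore stands apart only from compound 1, not from compound 2.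

Compound 4 `COc1ccc(S(=O)(=O)N(C)c2ccc(C(O)(C(F)(F)F)C(F)(F)F)cc2)cc1` differs from compound 3 by methoxy in place of hydrogen on an aromatic carbon. None of the three measured steps changes a group on the ring attached to the sulfonyl; each swaps one whole group on the ring nitrogen for another, and even those swaps moved the numbers little. The measured steps give no direct guide to this change. The expected step of no change at the digits printed from compound 3 to compound 4 (within the scatter) is therefore within the scatter. Compound 4 is estimated at about 16000 nM, within a range from 8000 nM to 32000 nM.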

Compound 4, half-maximal cytotoxic concentration: 7900 nM
The estimate for compound 4 lay 2.0-fold (0.31 log units) above the measured number, outside the stated range (below it).
By their numbers in this assay, from the lowest: compound 4; then compounds 3, 2 and 1 (each within the scatter of the next, the first and the last beyond it).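

In this assay, the ring attached to the sulfonyl now has a measured change of its own: methoxy in place of hydrogen, para to a large group, gives a 2.0-fold lower number from compound 3 to compound 4 (0.31 log units; beyond the scatter), a modest step toward higher toxicity in this test. For the compounds shown here, all the earlier steps swapped a whole group on the ring nitrogen, so this is the first sign that a group of only 2 heavy atoms on this outer ring can move the number beyond the scatter. No measurement shown gives a reason for this shift.

On these data alone, it remains open whether this step is specific to methoxy or would also appear with another group at this place, such as a chlorine atom, a hydroxyl or an amine. As far as these compounds go, it is equally open whether methoxy elsewhere on this ring would give a similar number.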